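The source may report more compounds than this note shows. Statements on the series, on what has been measured and on what is new or still open speak of the compounds shown alone.

Within the data shown here, compound 3 `Nc1scc(CN2CCN(c3cc(F)cc(F)c3)CC2)c1C(=O)c1ccc(Cl)cc1` sits at the strong end of the three numbers measured so far. In a functional assay on CHO cells with adenosine receptor A1 (Homo sapiens) as the target, read by cAMP accumulation and immunoassay, with a stated time of 6 min, tested at 10 uM (on this read-out higher numbers stand for a weaker effect at the one concentration tested and lower numbers for a stronger effect), compound 3 gives -79%, while compound 1 `Nc1scc(CN2CCN(c3cc(Cl)cc(Cl)c3)CC2)c1C(=O)c1ccc(Cl)cc1` gives -74% and compound 2 `Nc1scc(CN2CCN(c3ccncc3)CC2)c1C(=O)c1ccc(Cl)cc1` gives -15%; the gap to compound 1 is within the scatter, the gap to compound 2 is not. The two measured steps that end at compound 3 show this: a number 5 percentage points lower from compound 1 to compound 3 (within the scatter), and a number 64 percentage points lower from compound 2 to compound 3 (beyond the scatter).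

Compound 4 `Nc1scc(CN2CCN(c3c(F)cccc3F)CC2)c1C(=O)c1ccc(Cl)cc1` keeps every atom of compound 3 and differs only in where the fluorines stand: 2,6-difluorophenyl in place of 3,5-difluorophenyl on an amine nitrogen in a ring. Among the measured compounds shown here, no measured pair tests a move of substituents from one position to another on this phenyl ring; the only step among halogenated phenyls, a number 5 percentage points lower from compound 1 to compound 3 (within the scatter), exchanged chlorine for fluorine at unchanged positions and stayed within the scatter, and the one large change, a number 59 percentage points higher from compound 1 to compound 2 (beyond the scatter), replaced the phenyl ring with a pyridine. Compound 4 still carries a difluorophenyl on the ring nitrogen, so a number close to that of compound 3 is expected, with the step of a number 17 percentage points higher from compound 3 to compound 4 (beyond the scatter) estimated to stay within the scatter but carrying real uncertainty toward weaker values. For compound 4 the estimate in this assay is -62%, with a range from -88% to -20%.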

Compound 4, a percentage reported as activity, at one concentration (the size of the read-out at that concentration, not a potency): -80%
The estimate for compound 4 lay 18 percentage points above the measured number; the range from low to high includes it.
By their numbers in this assay, from the lowest: compounds 4, 3 and 1 (each within the scatter of the next); then compound 2.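

Among these compounds, the two placements of fluorine on this phenyl ring, 3,5-difluorophenyl and 2,6-difluorophenyl, cannot be told apart in this assay, with a number 1 percentage points lower from compound 3 to compound 4 (within the scatter), so this is the first sign that the read-out at this place on the ring nitrogen tolerates a shift in where the two fluorines stand, at least for this pair. Compound 4 also falls in with the 3,5-dichlorophenyl compound, with a number 6 percentage points lower from compound 1 to compound 4 (within the scatter), whereas a number 65 percentage points lower from compound 2 to compound 4 (beyond the scatter) keeps the one large gap, so among these four compounds the only clear division lies between the three halogenated phenyls and pyridin-4-yl. Nothing available explains why the fluorine placement makes so little difference here or why pyridin-4-yl stands apart.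

The compounds shown leave open whether an unsubstituted phenyl or a 3,5-dimethoxyphenyl would group with the halogenated phenyls or with compound 2, and whether a pyridin-3-yl would share the number of pyridin-4-yl. Because each number comes from a single concentration, they also leave open whether compounds 1, 3 and 4 would separate in a full concentration series.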